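Swapping Methyl for Fluoro on a Receptor Antagonist Core

This account rests on a few compounds, and the source may have more. Where it says the series, first, only, none or still open, it means among the compounds named here.

Compound 1 `Cc1ccc2c(c1)c(Sc1ccc(Cl)cc1)c(C)n2CC(=O)O`: 15 nM
Compound 2 `Cc1c(S(=O)(=O)c2ccc(Cl)cc2)c2cc(F)ccc2n1CC(=O)O`: 7.1 nM
Compound 3 `COc1ccc(Sc2c(C)n(CC(=O)O)c3ccc(C)cc23)cc1`: 7.1 nM

In an assay on isolated protein for displacement of a labelled ligand from prostaglandin D2 receptor 2 (Homo sapiens) (on this read-out lower numbers stand for stronger inhibition and higher numbers for weaker inhibition), compound 1 gives 15 nM, the highest of the three numbers, with both other compounds sitting lower by amounts beyond the scatter. Compound 4 `Cc1c(Sc2ccc(Cl)cc2)c2cc(F)ccc2n1CC(=O)O` differs from compound 1 by fluoro in place of methyl on an aromatic carbon. Going by the values given here, no measured step tells directly what this swap does: the only single-place step, a 2.1-fold lower number from compound 1 to compound 3 (0.32 log units; beyond the scatter), concerns a different position. Compound 2, which carries fluoro at this same place alongside other changes, gives 7.1 nM, so fluoro there is at least compatible with a lower number. A small step of a 1.5-fold lower number from compound 1 to compound 4 (0.18 log units; within the scatter) is therefore expected, within the scatter. Compound 4 is estimated at 10 nM with a range of 4 nM to 30 nM.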

Compound 4, half-maximal inhibitory concentration: 1.6 nM
For compound 4 the middle estimate is 6.3-fold (0.80 log units) above the measured one, and the stated range ends above it.
By their numbers in this assay, from the lowest: compound 4; then compounds 2 and 3 (each within the scatter of the next); then compound 1.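

In this assay, fluoro in place of methyl on this aromatic carbon gives a 9.4-fold lower number from compound 1 to compound 4 (0.97 log units; beyond the scatter) and so shows that this one place on the shared core can move the number substantially. Going by these compounds alone, this step is larger than the only earlier single-place step, which was at a different position (a 2.1-fold lower number from compound 1 to compound 3 (0.32 log units; beyond the scatter)). Nothing measured here accounts for the size of the change. Going by these compounds, whether a nitrile or a trifluoromethyl on this same carbon would lower the number further remains open.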